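Swapping ethyl for 1-propylazetidin-3-yl on compound 3

A few compounds are considered here, and "the series" means these few. Any claim that something is new, unique, unknown or untested is made for them only; others in the source may bear on it.

In a functional assay on HeLa cells (Homo sapiens) for antiproliferative activity, read by MTT assay, with a stated time of 48 h (on this read-out lower numbers stand for stronger inhibition and higher numbers for weaker inhibition), compound 1 `CCOc1cc(-c2ccc3[nH]ccc3c2)cn2c(-c3cc(OC)c(OC)c(OC)c3)nnc12` gives 166 nM and compound 3 `CCOc1cc(-c2ccc3c(ccn3C)c2)cn2c(-c3cc(OC)c(OC)c(OC)c3)nnc12` gives 210 nM. Within the data shown here, these are the only two exact numbers so far, and they lie within the scatter of each other. Placing methyl on an aromatic nitrogen in place of hydrogen produces a 1.3-fold higher number from compound 1 to compound 3 (0.10 log units; within the scatter).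

Compound 2 `COc1cc(-c2nnc3c(OC4CN(C(C)(C)C)C4)cc(-c4ccc5[nH]ccc5c4)cn23)cc(OC)c1OC` is reported only as a limit, > 10000 nM. Its 1-(tert-butyl)azetidin-3-yl in place of ethyl on an oxygen on an aromatic ring produces an at least 60-fold higher number from compound 1 to compound 2 (1.77 log units; beyond the scatter).

Compound 4 `CCCN1CC(Oc2cc(-c3ccc4c(ccn4C)c3)cn3c(-c4cc(OC)c(OC)c(OC)c4)nnc23)C1` carries a closely related change on compound 3: 1-propylazetidin-3-yl in place of ethyl on an oxygen on an aromatic ring. The step to compound 2 is the measured guide here, and it points to a large loss of activity, with an at least 60-fold higher number from compound 1 to compound 2 (1.77 log units; beyond the scatter). It is a single example, however, and its group carries tert-butyl rather than propyl on the ring nitrogen, so the size of the new step remains uncertain. The methyl step adds little to this expectation, as it stays within the scatter. A clear rise in the number is therefore expected in this assay, with an estimated 33-fold higher number from compound 3 to compound 4 (1.52 log units; beyond the scatter). For compound 4 the estimate is 7000 nM, with an expected range from 1200 nM to 20000 nM.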

Compound 4, half-maximal inhibitory concentration: 211 nM
The estimate for compound 4 lay 33-fold (1.52 log units) above the measured number; the measured number lies below the stated range.
By their numbers in this assay, from the lowest: compounds 1, 3 and 4 (each within the scatter of the next). At a limit, above all of these: compound 2.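

In this assay, replacing ethoxy with (1-propylazetidin-3-yl)oxy on compound 3 gives a 1.0-fold higher number from compound 3 to compound 4 (0.00 log units; within the scatter). This oxygen on an aromatic ring can therefore carry a group containing a four-membered non-aromatic ring and a nitrogen with no change beyond the scatter, so a larger group here need not cost activity. Among these compounds, the only earlier change at this place gave an at least 60-fold higher number from compound 1 to compound 2 (1.77 log units; beyond the scatter), and the new pair shows that the azetidine ring on this oxygen does not by itself bring such a rise.

Compound 2 differs from compound 4 in more than one place, with tert-butyl instead of propyl on the ring nitrogen and hydrogen instead of methyl on the aromatic nitrogen, so the compounds shown cannot tell which difference goes with its limit: the limit of > 10000 nM in this assay, at which 1 of the 4 values shown sits. On these data alone, it also stays open how this oxygen would respond to an azetidine with only hydrogen on its nitrogen, a longer chain such as butyl on that nitrogen, or an open-chain amine such as 2-(dimethylamino)ethyl.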